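Isobutoxy in Place of 4-Nitrophenyl on the Carbonyl

The source may report more compounds than this note shows. Statements on the series, on what has been measured and on what is new or still open speak of the compounds shown alone.

Compound 1 `CCc1cc(S(=O)(=O)N2C[C@H](c3ccccc3)NC2=O)ccc1NC(=O)c1ccc([N+](=O)[O-])cc1` and compound 2 `CCOC(=O)Nc1ccc(S(=O)(=O)N2C[C@H](c3ccccc3)NC2=O)c(C)c1C` share a core and were both tested in a functional assay on NCI-H460 cells (Homo sapiens) for cytotoxicity, read by MTT assay; a lower number here means a stronger inhibitor, a higher number a weaker inhibitor. In this assay compound 1 gives 800 nM, the highest of the two numbers, while compound 2 gives 300 nM, a gap beyond the scatter. Compound 3 `CCc1cc(S(=O)(=O)N2C[C@H](c3ccccc3)NC2=O)ccc1NC(=O)OCC(C)C` awaits measurement; it differs from compound 1 by isobutoxy in place of 4-nitrophenyl on a carbonyl carbon. For the measured compounds named here, no single-change step between measured compounds is available, and compound 2 differs from compound 1 in more than one place. Given compound 2 at 300 nM, the estimated step is a 1.8-fold lower number from compound 1 to compound 3 (0.25 log units; within the scatter), a modest move toward a lower number. Compound 3 is thus expected near 450 nM, within 150 nM to 1300 nM.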

Compound 3, half-maximal inhibitory concentration: 80 nM
Beside the measured number, compound 3's estimate is 5.6-fold (0.75 log units) above it; measured number outside the range, below it.
By their numbers in this assay, from the lowest: compound 3; then compound 2; then compound 1.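

At this carbonyl carbon the aromatic ring is not needed for a low number: in this assay, isobutoxy in place of 4-nitrophenyl gives a 10-fold lower number from compound 1 to compound 3 (1.00 log units; beyond the scatter) on the otherwise unchanged core of compound 1. A group with no ring can therefore take this place without any loss. Nothing measured here explains the change.

The compounds shown leave open whether the oxygen or the branched chain of isobutoxy matters more. A straight butoxy chain or a phenoxy group on the same carbonyl carbon would help separate the two.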